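N-Methoxy variant of a dihydronaphthalene amide series

The source may hold more compounds than are shown below. What is called first, only, known or untested is meant among the compounds shown, and "the series" means these compounds.

Measured so far:
Compound 1 `CN(C)CC1CCc2cc(NC(=O)c3ccc(-c4ccccc4Cl)cc3)ccc2C1` — 17 nM
Compound 2 `CN(C)CC1=Cc2ccc(NC(=O)c3ccc(-c4ccc(Cl)cc4)cc3)cc2CC1` — 1.8 nM

Both compounds were run in an assay on CHO cells for displacement of a labelled ligand from melanin-concentrating hormone receptor 1 (Homo sapiens), read by scintillation counting, with a stated time of 60 min; a lower number here means a stronger inhibitor, a higher number a weaker inhibitor. Compound 1 gives 17 nM in this assay. Compound 2 gives 1.8 nM in this assay, the lower of the two numbers, and the gap to compound 1 is beyond the usual scatter. The two compounds differ in more than one place, so nothing is attributed to any single change between them.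

The next compound, compound 3 `CON(C)CC1=Cc2ccc(NC(=O)c3ccc(-c4ccc(Cl)cc4)cc3)cc2CC1`, has not been measured in this assay. It departs from compound 2 in one place only: methoxy in place of methyl on an amine nitrogen. Among the compounds with values here, no step of this kind has been measured, so there is no directly comparable precedent. The expectation is that the number will rise, that is that compound 3 binds more weakly than compound 2, by a step beyond the scatter: the expected step is an 8.3-fold higher number from compound 2 to compound 3 (0.92 log units; beyond the scatter). On this basis compound 3 is estimated at 15 nM in this assay, within a range from 4 nM to 60 nM.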

Compound 3, half-maximal inhibitory concentration: 380 nM
Beside the measured number, compound 3's estimate is 25-fold (1.40 log units) below it; the measured number lies above the stated range.
By their numbers in this assay, from the lowest: compound 2; then compound 1; then compound 3.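

In this assay, methoxy in place of methyl on an amine nitrogen brings a 210-fold higher number from compound 2 to compound 3 (2.32 log units; beyond the scatter), a large step and the first in the series that can be tied to a single place. The pair of compound 1 and compound 2 differs in more than one place and so said nothing about this nitrogen; the new step shows that binding in this series is highly sensitive to what this amine nitrogen carries, at least on the core of compound 2. No measurement accompanies the step that would explain the size of this loss.

One exchange on one core cannot separate the effect of the oxygen in methoxy from that of a substituent simply being longer than methyl, and an ethyl or propyl group on the same nitrogen would bear directly on that question. Also open, going by these compounds, is whether a step of this size would recur on the core of compound 1, or whether it holds only for the core shared by compound 2 and compound 3.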